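Benzoyl in Place of the Amide Hydrogen

The source may report more compounds than this note shows. Statements on the series, on what has been measured and on what is new or still open speak of the compounds shown alone.

Compound 1 `Cc1nc(NC(=O)c2ccccc2)c2nn(-c3ccccc3)cc2n1`: 19.7 nM
Compound 2 `O=C(Nc1nc(-c2ccccc2)nc2cn(-c3ccccc3)nc12)c1ccccc1`: 65 nM

Of the compounds shown here, two have so far been tested in a functional assay on CHO cells for inhibition of adenosine receptor A3 (Homo sapiens), read by cAMP accumulation, with a stated time of 10 min, in the presence of a further agent that is not named here; on this read-out lower numbers stand for stronger inhibition and higher numbers for weaker inhibition. Compound 1 gives 19.7 nM, and compound 2 gives 65 nM. Going by the values given here, compound 1 therefore has the lower of the two numbers, and its only neighbour is compound 2, with a 3.3-fold higher number from compound 1 to compound 2 (0.52 log units; beyond the scatter), where the change is phenyl in place of methyl on an aromatic carbon. Compound 3 `Cc1nc(N(C(=O)c2ccccc2)C(=O)c2ccccc2)c2nn(-c3ccccc3)cc2n1` is not yet measured. It differs from compound 1 by benzoyl in place of hydrogen on an amide-type nitrogen. Among the compounds with values here, the one measured step concerns an aromatic carbon of the shared core, not the amide nitrogen, so no measured step bears on this change, and the expectation for compound 3 in this assay rests on the structural change alone. Compound 3 is expected to show a 3.6-fold higher number from compound 1 to compound 3 (0.55 log units; beyond the scatter), a weaker inhibition than compound 1, with a wide range because nothing measured tests this nitrogen. The estimate for compound 3 in this assay is 70 nM, between 15 nM and 400 nM.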

Compound 3, half-maximal inhibitory concentration: 115 nM
Compound 3: the middle estimate sits 1.6-fold (0.22 log units) below what was measured; the range from low to high includes it.
By their numbers in this assay, from the lowest: compound 1; then compounds 2 and 3 (each within the scatter of the next).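

In this assay, the amide-type nitrogen now has a measured step of its own, which the earlier pair, changed only at an aromatic carbon of the shared core, could not give. Benzoyl in place of the amide hydrogen gives a 5.8-fold higher number from compound 1 to compound 3 (0.77 log units; beyond the scatter), so a change at this nitrogen weakens inhibition by more than the scatter, yet compound 3, which carries two benzoyl groups on that nitrogen and no amide hydrogen, still gives 115 nM. Nothing available accounts for this loss of inhibition.

With only hydrogen and benzoyl compared at this nitrogen, the compounds shown cannot separate the loss of the amide hydrogen from the arrival of the added aromatic ring, and a smaller group such as methyl or acetyl in the same place would bear on that question. From the compounds shown here alone, it also remains open whether the same benzoyl change would give a step of similar size on the core of compound 2, where phenyl stands in place of methyl on the aromatic carbon.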